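Hydrazone thiazoles: aryl variation on the shared core

The source may hold more compounds than are shown below. What is called first, only, known or untested is meant among the compounds shown, and "the series" means these compounds.

Compound 1 `COc1cc(/C=N/Nc2nc(-c3ccccc3)cs2)c(Br)c(Br)c1OC` is the reference point of this small set. In a functional assay on U-87MG ATCC cells for inhibition, with U-87 MG (Homo sapiens) as the target, read by MTT assay, with a stated time of 48 h (on this read-out higher numbers stand for weaker inhibition and lower numbers for stronger inhibition), compound 1 gives 20100 nM, the lowest of the two numbers recorded. Compound 2 `COc1cc(/C=N/Nc2nc(-c3ccccc3)cs2)cc(Br)c1OC` is its nearest neighbour, and in this assay compound 2 gives 74100 nM; the step of a 3.7-fold higher number from compound 1 to compound 2 (0.57 log units; beyond the scatter) comes from hydrogen in place of bromo on an aromatic carbon. Compound 3 `COc1cc(/C=N/Nc2nc(-c3cc(C(F)(F)F)cc(C(F)(F)F)c3)cs2)c(Br)c(Br)c1OC` carries two trifluoromethyl groups on the phenyl ring attached to the core. In this assay, among the compounds with values here, compound 3 reaches only > 100000 nM, which is a limit of the measurement and not a number; it is the one value sitting at the limit of > 100000 nM in this assay, at which 1 of the 3 values shown sits.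

Compound 4 `COc1cc(/C=N/Nc2nc(-c3ccc(F)c(F)c3)cs2)c(Br)c(Br)c1OC` differs from compound 1 by 3,4-difluorophenyl in place of phenyl on an aromatic carbon. Within the data shown here, no measured step alters this position: the only step recorded, that from compound 1 to compound 2, concerns the bromo substituents elsewhere on the core, so it gives no direct guidance. The pair compound 1 and compound 3 shows that a heavily substituted phenyl at this position is associated with a value at the limit, while the difluoro change is far smaller in what it adds. A modest weakening, or no step beyond the scatter, is therefore expected in this assay. Compound 4 is estimated at 35000 nM, within a range from 12000 nM to 100000 nM, which means an expected step of a 1.7-fold higher number from compound 1 to compound 4 (0.24 log units; within the scatter).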

Compound 4, half-maximal inhibitory concentration: 19600 nM
Compound 4: middle estimate off by 1.8-fold (0.25 log units), on the high side; the measured number falls inside the stated range.
By their numbers in this assay, from the lowest: compounds 4 and 1 (each within the scatter of the next); then compound 2. At a limit, above all of these: compound 3.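

Notes on the position next to the ring nitrogen: the change to 3,4-difluorophenyl in place of phenyl gives a 1.0-fold lower number from compound 1 to compound 4 (0.01 log units; within the scatter) in this assay, the first measured step at this position, and it does not separate the two aryl groups. Adding fluorine to the phenyl at this position therefore does not by itself go with a loss in this read-out, although this rests on a single pair, and compound 3, with two trifluoromethyl groups on the same phenyl, goes against any general reading of the position as tolerant of substitution. Compound 3 stands at > 100000 nM, which is a limit and not a number: the limit of > 100000 nM in this assay, at which 1 of the 4 values shown sits.

The compounds shown cannot tell whether the contrast between compound 3 and compound 4 follows the kind, the number or the placing of the substituents on the phenyl, and they do not show whether the bromo step seen with the plain phenyl carries over to 3,4-difluorophenyl. Also open, going by these compounds, is how this position responds to a phenyl bearing an amine or a carboxylic acid, or to a methoxy group on the same ring.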